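The compounds below may be only part of what the source reports. "The series", "measured", "known", "first", "only" and "open" are said of these compounds alone.

Of the compounds shown here, three have been measured in an assay on isolated protein for inhibition of serine/threonine-protein kinase TNNI3K (Homo sapiens); a higher number here means a weaker inhibitor, a lower number a stronger inhibitor. Compound 1, with the structure `CCNc1cc(Oc2ccc(NC(=O)Nc3cccc(C(F)(F)F)c3)cc2)ncn1`, gives 25 nM. Compound 3, with the structure `CNc1cc(Oc2ccc(NC(=O)Nc3cccc(C(F)(F)F)c3)c(F)c2F)ncn1`, gives 20 nM; the two numbers lie within the scatter of each other, so nothing separates them. Compound 2, with the structure `CNc1cc(Oc2ccc(NC(=O)Nc3ccccc3)cc2)ncn1`, gives 6300 nM, a much higher number than that of compound 1, and that gap lies well beyond the scatter. Compound 1 therefore stands in the middle of the three numbers, close to compound 3 and far from compound 2.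

The compound not yet measured is compound 4, with the structure `CCCNc1cc(Oc2ccc(NC(=O)Nc3cccc(C(F)(F)F)c3)cc2)ncn1`. It differs from compound 1 in one place: methyl in place of hydrogen on a saturated chain carbon, two bonds along the chain from a nitrogen on an aromatic ring. This lengthens the chain on the nitrogen at the shared core by one carbon and changes nothing in the urea or in the trifluoromethyl-bearing ring, the part that separates compound 1 from compound 2. Among the compounds with values here, no step between two measured compounds isolates this kind of change. The expectation for this assay is a step from compound 1 to compound 4 of a 1.2-fold higher number from compound 1 to compound 4 (0.08 log units; within the scatter), small and in no set direction, within the usual scatter. Compound 4 is thus estimated at 30 nM, with a likely range from 10 nM to 90 nM.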

Compound 4, half-maximal inhibitory concentration: 32 nM
Estimate against measurement, compound 4: 1.1-fold (0.03 log units) below; the measured number falls inside the stated range.
By their numbers in this assay, from the lowest: compounds 3, 1 and 4 (each within the scatter of the next); then compound 2.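

In this assay, the swap of ethylamino for propylamino gives a 1.3-fold higher number from compound 1 to compound 4 (0.11 log units; within the scatter), so the two compounds cannot be separated. This is the only step among the compounds shown that isolates a change on this chain, and it shows that one further carbon at this position can be carried without a difference beyond the scatter. No measurement shown bears on why this step is so small.

One added carbon says little about how far the chain can grow, so a butyl or pentyl chain on the same nitrogen could behave differently. The compounds shown also leave open whether a branched isopropyl group, a cyclopropyl ring, or a hydroxyl or amine at the chain end would fit as well.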